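The source may hold more compounds than are shown below. What is called first, only, known or untested is meant among the compounds shown, and "the series" means these compounds.

Going by the values given here, compound 2 `Cc1ccc(S(=O)(=O)n2cc(COC3=C/C(=N\c4ccc(Br)cc4)c4ccccc4C3=O)nn2)cc1` is the one compound here with a number in a functional assay on PC-3 cells (Homo sapiens) for cytotoxicity, read by MTT assay, with a stated time of 72 h; on this read-out lower numbers stand for stronger inhibition and higher numbers for weaker inhibition: in that assay compound 2 gives 3410 nM. Compound 1 `COc1ccc(/N=C2\C=C(OCc3cn(S(=O)(=O)c4ccc(C)cc4)nn3)C(=O)c3ccccc32)cc1` reaches only a limit of this assay, > 20000 nM, which the limit of > 20000 nM in this assay, at which 1 of the 2 values shown sits, records. Among the compounds with values here, the one measured step, an at least 5.8-fold lower number from compound 1 to compound 2 (0.76 log units; beyond the scatter), therefore starts from a limit rather than a number. Compound 3 `Cc1ccc(S(=O)(=O)n2cc(COC3=C/C(=N\c4ccccc4)c4ccccc4C3=O)nn2)cc1` differs from compound 2 by hydrogen in place of bromo on an aromatic carbon. The step from compound 1 to compound 2 concerns the same aromatic carbon but a different exchange, so it bears only loosely on the present one; what it shows is that the group on this carbon can move the number beyond the scatter. Taking bromo away altogether is expected to push the number up again, though not as far as the limit seen for compound 1. The estimated step is a 2.3-fold higher number from compound 2 to compound 3 (0.37 log units; beyond the scatter). Compound 3 is thus expected to give about 8000 nM in this assay, with a range from 2500 nM to 25000 nM.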

Compound 3, half-maximal inhibitory concentration: > 20000 nM
Compound 3 ended at the assay's limit; the forecaster's own chance of this, stated with the estimate: 25%; middle value at least 2.5-fold (0.39 log units) from the limit.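

The change from 4-bromophenyl to phenyl comes with an at least 5.8-fold higher number from compound 2 to compound 3 (0.76 log units; beyond the scatter), so on this aromatic carbon the bromo is now compared with hydrogen as well as with methoxy. In this assay, neither hydrogen nor methoxy on this carbon gives a number, and the step between compound 1 and compound 3 cannot be read because both of its ends are limits. Among the three compounds, the bromo of compound 2 is therefore the only group on this carbon that brings the read-out inside the range of the assay, while the other two compounds stop at the same limit: the limit of > 20000 nM in this assay, at which 2 of the 3 values shown sit.

What the compounds shown leave open is whether this belongs to bromo alone or would also appear with chloro, iodo, methyl or trifluoromethyl on the same carbon. They also leave open how far compound 1 and compound 3 lie beyond their limit, whether those two differ at all, and so how large the full step from compound 2 to compound 3 really is.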